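Allyl to propargyl on the shared core

This account rests on a few compounds, and the source may have more. Where it says the series, first, only, none or still open, it means among the compounds named here.

In a functional assay on MDA-MB-231 cells (Homo sapiens), read by microscopy and transwell migration, with a stated time of 24 h (on this read-out lower numbers stand for stronger inhibition and higher numbers for weaker inhibition), compound 1 `CCCn1c(-c2ccc(C)cc2C)cs/c1=N\C(=O)c1ccccc1` gives 292 nM and compound 2 `C=CCn1c(-c2ccc(C)cc2C)cs/c1=N\C(=O)c1ccccc1` gives 456 nM. Among the measured compounds shown here, compound 2 therefore stands within the scatter of compound 1, the only other number available. Compound 3 `C#CCn1c(-c2ccc(C)cc2C)cs/c1=N\C(=O)c1ccccc1` carries ethynyl in place of vinyl on a saturated chain carbon bound to an aromatic nitrogen. For the measured compounds named here, the only measured step at this place is a 1.6-fold higher number from compound 1 to compound 2 (0.19 log units; within the scatter), and it stays within the scatter. No step beyond the scatter is therefore expected in this assay. The expected step is a 1.2-fold lower number from compound 2 to compound 3 (0.08 log units; within the scatter). Compound 3 is estimated at 380 nM, with an expected range of 170 nM to 850 nM.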

Compound 3, half-maximal inhibitory concentration: 3890 nM
Compound 3: middle estimate off by 10-fold (1.01 log units), on the low side; the whole stated range lies below it.
By their numbers in this assay, from the lowest: compounds 1 and 2 (each within the scatter of the next); then compound 3.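

In this assay the place on a saturated chain carbon bound to an aromatic nitrogen proves sensitive to the group it carries, which the first pair could not show: ethynyl in place of vinyl gives an 8.5-fold higher number from compound 2 to compound 3 (0.93 log units; beyond the scatter) and ethynyl in place of ethyl gives a 13-fold higher number from compound 1 to compound 3 (1.12 log units; beyond the scatter). Ethyl and vinyl stay within the scatter of each other, so the loss appears only with the triple bond. No measurement at hand bears on the reason for this step. On these data alone, whether a longer chain or a terminal amine at this place returns to the range of compound 1 remains open. Also open, as far as these compounds go, is whether the ethynyl step holds with other groups on the shared core.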